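The source may report more compounds than this note shows. Statements on the series, on what has been measured and on what is new or still open speak of the compounds shown alone.

In a functional assay on HCT-15 cells (Homo sapiens) for inhibition, read by sulforhodamine B assay, with a stated time of 48 h (on this read-out higher numbers stand for weaker inhibition of growth and lower numbers for stronger inhibition of growth), compound 2 (`COc1cc(-c2nn(-c3cccc(NC(=O)c4cccc(C(F)(F)F)c4)c3)cc2-c2ccncc2)ccc1Cl`) gives > 50000 nM as its result. This is a limit and not a number, so the starting point of the step is poorly defined. Compound 4 (`COc1cc(-c2nn(-c3cccc(NC(=O)Nc4ccc(Cl)c(C(F)(F)F)c4)c3)cc2-c2ccncc2)ccc1Cl`) changes compound 2 in one place: (4-chloro-3-(trifluoromethyl)phenyl)amino in place of 3-(trifluoromethyl)phenyl on a carbonyl carbon is the difference, in which (4-chloro-3-(trifluoromethyl)phenyl)amino replaces 3-(trifluoromethyl)phenyl on a carbonyl carbon.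

Two comparisons bear on this change. Compound 3 (`COc1cc(-c2nn(-c3cccc(NC(=O)c4ccc(Cl)c(C(F)(F)F)c4)c3)cc2-c2ccncc2)ccc1Cl`) gives > 32500 nM as its result, and this too is a limit. Adding the chloro alone is therefore a step that the two limits leave unreadable from compound 2 to compound 3 and offers no measured size. The stronger clue is compound 1 (`COc1cc(-c2nn(-c3cccc(NC(=O)Nc4cc(C(F)(F)F)cc(C(F)(F)F)c4)c3)cc2-c2ccncc2)ccc1Cl`), which also has an amino group on the carbonyl carbon, although its outer ring carries different groups. Compound 1 gives 1640 nM as a true number, the only one among the three measured compounds.

This single comparison suggests a large move towards stronger inhibition of growth, but it rests on one compound, and compound 4 may not match it closely. The expected change is an at least 16-fold lower number from compound 2 to compound 4 (1.22 log units; beyond the scatter) in this direction. For compound 4 the estimated value is 3000 nM with an expected range from 1000 nM to 15000 nM in this assay for now.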

Compound 4, concentration for total growth inhibition: 7050 nM
Compound 4: the middle estimate sits 2.4-fold (0.37 log units) below what was measured; the range from low to high includes it.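

In this assay, putting an amino group on the carbonyl carbon while the outer ring stays the same gives an at least 4.6-fold lower number from compound 3 to compound 4 (0.66 log units; beyond the scatter), and the same change made together with the chloro gives an at least 7.0-fold lower number from compound 2 to compound 4 (0.85 log units; beyond the scatter), so this position now has a readable result for the amino group on a single outer ring. The second of these steps is only a minimum size because compound 2 stands at a limit of the assay and not at a number: the limit of > 50000 nM in this assay, at which 1 of the 4 values shown sits. The first is likewise only a minimum because compound 3 also stands at a limit of the assay: the limit of > 32500 nM in this assay, at which 1 of the 4 values shown sits.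

The compounds shown leave open how large the true gain is, and whether the amino group alone would give a similar step on the 3-(trifluoromethyl)phenyl ring without the chloro. They also leave open whether an oxygen atom or a methylene group in place of the amino group on the same carbonyl carbon would keep any of this gain.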